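Fluorophenylamino isomers on the shared core

This account rests on a few compounds, and the source may have more. Where it says the series, first, only, none or still open, it means among the compounds named here.

Measured so far in an in vitro assay on HEK-tsA201 cells for antagonist activity at Neuronal acetylcholine receptor; alpha4/beta2 (Homo sapiens), read by fluorescence and calcium flux; a lower number here means a stronger inhibitor, a higher number a weaker inhibitor:
- compound 1 `CCCOc1ccc(C(=O)Nc2cccc(Br)n2)cc1` gives 80700 nM
- compound 2 `CCCOc1ccc(C(=O)Nc2cccc(CC)n2)cc1` gives 37600 nM
- compound 3 `CCCOc1ccc(C(=O)Nc2cccc(Nc3ccccc3F)n2)cc1` gives > 100000 nM, which is a limit of the assay, not a number

Compound 3 therefore sits at the limit of > 100000 nM in this assay, at which 1 of the 3 values shown sits, and is the weakest point on the numbers shown, with an at least 2.6-fold higher number from compound 2 to compound 3 (0.42 log units; beyond the scatter) beyond the scatter and an at least 1.2-fold higher number from compound 1 to compound 3 (0.09 log units; that floor lies within the scatter) whose floor is within it. Among the compounds with values here, the bromo to ethyl step, a 2.1-fold lower number from compound 1 to compound 2 (0.33 log units; beyond the scatter), is the only one with a full number at both ends.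

Compound 4 `CCCOc1ccc(C(=O)Nc2cccc(Nc3cccc(F)c3)n2)cc1` is a positional isomer of compound 3: 3-fluorophenyl in place of 2-fluorophenyl on a nitrogen on an aromatic ring. Within the data shown here, no measured step changes the position of a fluorine on this phenyl, so none bears directly on it; the two steps into compound 3 only show that the (2-fluorophenyl)amino group leaves the value at the limit. Moving the fluorine within the same group is expected to give no step beyond the scatter, a step that the limit leaves unreadable from compound 3 to compound 4. Compound 4 is thus estimated at 150000 nM, most likely again reported as a limit, within 60000 nM to 400000 nM.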

Compound 4, half-maximal inhibitory concentration: > 100000 nM
Compound 4: only a limit was reported (the forecaster's own chance of this, stated with the estimate: 70%); the middle value lies beyond the limit too.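

In this assay compound 4 gives > 100000 nM, which is a limit of the assay and not a number. Set against ethyl, the (3-fluorophenyl)amino group gives an at least 2.6-fold higher number from compound 2 to compound 4 (0.42 log units; beyond the scatter), while set against bromo it gives only an at least 1.2-fold higher number from compound 1 to compound 4 (0.09 log units; that floor lies within the scatter), so the second comparison remains unresolved. The steps between the two fluorine isomers cannot be read, and moving the fluorine from 2-fluorophenyl to 3-fluorophenyl on this nitrogen does not bring a full number into view: the limit of > 100000 nM in this assay, at which 2 of the 4 values shown sit.

Any difference between compound 3 and compound 4 remains hidden in this series. Also open, from the compounds shown here alone, is whether a small amine such as methylamino, or a longer chain such as propyl in place of ethyl, would give a lower number than the ethyl of compound 2.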